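The source may report more compounds than this note shows. Statements on the series, on what has been measured and on what is new or still open speak of the compounds shown alone.

In a functional assay on HL-60 cells (Homo sapiens) for antiproliferative activity, read by MTT assay, with a stated time of 72 h (on this read-out lower numbers stand for stronger inhibition and higher numbers for weaker inhibition), compound 1 `COc1cc(C(=O)c2sc3ccccc3c2-c2ccccc2)cc(OC)c1OC` gives 1700 nM and compound 2 `COc1cc(C(=O)c2sc3ccccc3c2-c2ccc(C)cc2)cc(OC)c1OC` gives 1400 nM, so compound 2 stands level with compound 1 within the scatter. Compound 3 `COc1ccc(-c2c(C(=O)c3cc(OC)c(OC)c(OC)c3)sc3ccccc23)cc1` has methoxy in place of methyl on an aromatic carbon of compound 2: methoxy in place of methyl on an aromatic carbon. Going by the values given here, the only measured step that bears on this change is a 1.2-fold lower number from compound 1 to compound 2 (0.08 log units; within the scatter), which placed methyl on an aromatic carbon and stayed small. A step of about that size, none beyond the scatter, is therefore expected here. The expected change is a 1.4-fold lower number from compound 2 to compound 3 (0.15 log units; within the scatter). For compound 3 the estimate is 1000 nM, with an expected range of 300 nM to 3000 nM.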

Compound 3, half-maximal inhibitory concentration: 1600 nM
Compound 3: the middle estimate sits 1.6-fold (0.20 log units) below what was measured, and the stated range covers the measured number.
By their numbers in this assay, from the lowest: compounds 2, 3 and 1 (each within the scatter of the next).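

In this assay methoxy in place of methyl, para to a large group, gives a 1.1-fold higher number from compound 2 to compound 3 (0.06 log units; within the scatter) and methoxy in place of hydrogen gives a 1.1-fold lower number from compound 1 to compound 3 (0.03 log units; within the scatter). So hydrogen, methyl and methoxy, the last adding an oxygen and a hydrogen-bond acceptor, all stand level at this position within the scatter. Nothing measured here offers a reason for this.

As far as these compounds go, whether an amine, a carboxylic acid or a longer chain such as butoxy would stay level at this position remains open. So does whether methyl and methoxy stay level elsewhere on this ring.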